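The compounds below may be only part of what the source reports. "The series", "measured", "known", "first", "only" and "open" are said of these compounds alone.

Measured compounds in an ADME assay on Huh-7 cells (Homo sapiens) for cytotoxicity, with a stated time of 72 h; a lower number here means that less compound is tolerated, a higher number that more compound is tolerated:
- Compound 1, `CC(C)CCn1nc(-c2cccs2)c(O)c(C2=NS(=O)(=O)c3cc(S(=O)(=O)N(C)C)ccc3N2)c1=O`: "not determined" (no result reported)
- Compound 2, `CC(C)CCn1nc(C2CCCCC2)c(O)c(C2=NS(=O)(=O)c3cc(NS(C)(=O)=O)ccc3N2)c1=O`: > 1000 nM
- Compound 3, `COCCn1nc(-c2cccs2)c(O)c(C2=NS(=O)(=O)c3cc(NS(C)(=O)=O)ccc3N2)c1=O`: > 1000 nM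

Compound 3 stands only at a limit of this assay, not at a number. For compound 2 the value is likewise a limit. Compound 1 has no result. Among the measured compounds shown here, two of the three entries therefore sit at the limit of > 1000 nM in this assay, at which 2 of the 3 values shown sit, and no step between measured compounds can be drawn.

Compound 4, `CS(=O)(=O)Nc1ccc2c(c1)S(=O)(=O)N=C(c1c(O)c(-c3cccs3)nn(CC3(C(F)(F)F)CCC3)c1=O)N2`, carries 1-(trifluoromethyl)cyclobutyl in place of methoxymethyl on a saturated chain carbon bound to an aromatic nitrogen. With nothing measured on this change, the step from compound 3 to compound 4 is expected to be none beyond the scatter, a number no higher from compound 3 to compound 4 (the limit leaves the size open). Compound 4 is estimated at 1000 nM, within 500 nM to 3000 nM, and is expected most likely to return again only a limit.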

Compound 4, half-maximal cytotoxic concentration: > 1000 nM
Compound 4: only a limit was reported (the forecaster's own chance of this, stated with the estimate: 70%); the middle value sits exactly at the limit.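

Compound 3 and compound 4 both stand only at a limit, so no step can be read between them: the limit of > 1000 nM in this assay, at which 3 of the 4 values shown sit. The compounds shown leave open whether 1-(trifluoromethyl)cyclobutyl in place of methoxymethyl changes the read-out at all.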